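Swapping a Methoxyphenyl for a Pyridyl: Solubility Outlook

The compounds below may be only part of what the source reports. "The series", "measured", "known", "first", "only" and "open" are said of these compounds alone.

Compound 2 `CCOC(=O)C1=C(C)N/C(=C/c2cc(C)n(-c3cccc(OC)c3)c2C)C1=O` is one of two close analogues measured in a physicochemical assay for solubility, read by nephelometry, measured as kinetic solubility, at pH 2.0; on this read-out higher numbers stand for higher solubility and lower numbers for lower solubility. Compound 2 gives 6.3 ug/mL, the lower of the two numbers; compound 1 `CCOC(=O)C1=C(C)N/C(=C/c2cc(C)n(-c3ccc(CN(C)C)cc3)c2C)C1=O` gives 50 ug/mL. Within the data shown here, the single measured step, a 7.9-fold lower number from compound 1 to compound 2 (0.90 log units; beyond the scatter), is the only guide to how a group on this aromatic nitrogen moves the read-out.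

Compound 3 `CCOC(=O)C1=C(C)N/C(=C/c2cc(C)n(-c3ccncc3)c2C)C1=O` differs from compound 2 in one place: pyridin-4-yl in place of 3-methoxyphenyl on an aromatic nitrogen. Among the measured compounds shown here, no measured step exchanges a phenyl ring for a pyridine ring, so that one step bears only indirectly, showing that a change at this place can shift the number well beyond the scatter. On that basis compound 3 is expected to give a modest rise, a 3.2-fold higher number from compound 2 to compound 3 (0.50 log units; beyond the scatter), with wide uncertainty. The estimate for compound 3 is 20 ug/mL, within a range from 6 ug/mL to 70 ug/mL.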

Compound 3, solubility: 100 ug/mL
For compound 3 the middle estimate is 5.0-fold (0.70 log units) below the measured one; the whole stated range lies below it.
By their numbers in this assay, from the lowest: compound 2; then compounds 1 and 3 (each within the scatter of the next).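

Pyridin-4-yl in place of 3-methoxyphenyl on the aromatic nitrogen gives a 16-fold higher number from compound 2 to compound 3 (1.20 log units; beyond the scatter) in this assay, which shows that a large step at this position can come from exchanging one ring for another, with neither group carrying a net charge. The other new step, a 2.0-fold higher number from compound 1 to compound 3 (0.30 log units; within the scatter), puts compound 3 level with compound 1, so at this position a bare pyridin-4-yl ring and the 4-((dimethylamino)methyl)phenyl group cannot be told apart on this read-out. Nothing available here explains why the number moves with this change.

The change removes a methoxy group and adds a ring nitrogen at once, and a plain phenyl ring would be needed to separate those two parts. Going by these compounds, whether pyridin-3-yl or pyridin-2-yl, with the ring nitrogen placed differently, would match pyridin-4-yl remains open too.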